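This account rests on a few compounds, and the source may have more. Where it says the series, first, only, none or still open, it means among the compounds named here.

Compound 1, `Nc1ccc2nccc(SC3(C(=O)O)CCC3)c2c1`, gives 1790 nM in an assay on HEK293 cells for inhibition of solute carrier family 22 member 12 (Homo sapiens), read by scintillation counting, with a stated time of 12 min; a lower number here means a stronger inhibitor, a higher number a weaker inhibitor.
Compound 2, `N#CCOc1ccc2nccc(SC3(C(=O)O)CCC3)c2c1`, gives 680 nM in this assay.
Compound 3, `CNC(=O)COc1ccc2nccc(SC3(C(=O)O)CCC3)c2c1`, gives only a limit of the assay, > 10000 nM, in this assay.

Compound 3 thus stands at the top of the numbers shown, at the point where the assay reports no number, (the limit of > 10000 nM in this assay, at which 1 of the 3 values shown sits). Compound 4, `O=C(O)C1(Sc2ccnc3ccc(C(F)(F)F)cc23)CCC1`, has not yet been measured. It differs from compound 3 in one place: trifluoromethyl in place of (methylcarbamoyl)methoxy on an aromatic carbon. For the measured compounds named here, two measured steps bear on this change, both of them leading into the (methylcarbamoyl)methoxy group rather than out of it. Against amino on the same aromatic carbon, the group gave an at least 5.5-fold higher number from compound 1 to compound 3 (0.74 log units; beyond the scatter). Against cyanomethoxy, it gave an at least 14-fold higher number from compound 2 to compound 3 (1.16 log units; beyond the scatter). Removing the group is therefore expected to bring the number back down, but trifluoromethyl has no measured counterpart among these compounds, so how far it comes down is open. Compound 1 and compound 2, the two measured compounds that lack the group, sit a modest step apart (a 2.6-fold lower number from compound 1 to compound 2 (0.42 log units; beyond the scatter)). Compound 4 is therefore expected to land near those two, which means an expected step of an at least 6.6-fold lower number from compound 3 to compound 4 (0.82 log units; beyond the scatter). The estimate for compound 4 in this assay is 1500 nM, with a range from 400 nM to 6000 nM.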

Compound 4, half-maximal inhibitory concentration: 61.2 nM
Beside the measured number, compound 4's estimate is 25-fold (1.39 log units) above it; measured number outside the range, below it.
By their numbers in this assay, from the lowest: compound 4; then compound 2; then compound 1. At a limit, above all of these: compound 3.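

For the compounds shown here, the aromatic carbon that carries the changing group matters more in this assay than the earlier compounds showed: trifluoromethyl gives an 11-fold lower number from compound 2 to compound 4 (1.05 log units; beyond the scatter) and a 29-fold lower number from compound 1 to compound 4 (1.47 log units; beyond the scatter), both large steps, where amino and cyanomethoxy stood only a modest step apart. With its steps to all three other compounds beyond the scatter, compound 4 is the strongest inhibitor of the four, so a group with neither an amino nitrogen nor a chain bound through oxygen serves best at this position among those shown. The step of an at least 160-fold lower number from compound 3 to compound 4 (2.21 log units; beyond the scatter) is only a bound, because compound 3 rests at a limit of the assay: the limit of > 10000 nM in this assay, at which 1 of the 4 values shown sits.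

From the compounds shown here alone, whether the low number belongs to trifluoromethyl in particular, or would also come with a methyl group, a chlorine atom or a trifluoromethoxy group on the same aromatic carbon, stays open. Also open, going by these compounds, is whether the gain from trifluoromethyl would hold with an ester or an amide in place of the carboxylic acid on the shared core.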